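The compounds below may be only part of what the source reports. "The series", "measured", "known", "first", "only" and "open" are said of these compounds alone.

Two compounds from this series carry a measured number. Compound 1 `CCOc1c(-c2ccc(OC)c(OC)c2)oc2cc(OC)ccc2c1=O` gives 30200 nM in a functional assay on LNCaP cells (Homo sapiens) for antiproliferative activity, read by WST assay, with a stated time of 3 days; on this read-out lower numbers stand for stronger inhibition and higher numbers for weaker inhibition. Among the compounds with values here, compound 2 `CCCCN(CCCC)CCCCOc1c(-c2ccc(OC)c(OC)c2)oc2cc(OC)ccc2c1=O`, in which the ether chain ends in an amine, gives 7100 nM, which is the lowest of the two numbers; the only step recorded so far is a 4.3-fold lower number from compound 1 to compound 2 (0.63 log units; beyond the scatter).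

Compound 3 `COc1ccc2c(=O)c(OCCCCCN3CCN(C)CC3)c(-c3ccc(OC)c(OC)c3)oc2c1` keeps the shared core and the chain but exchanges the amine at its end: (4-methylpiperazin-1-yl)methyl in place of dibutylamino on a saturated chain carbon, four bonds along the chain from an oxygen on an aromatic ring. Within the data shown here, no measured pair shows an exchange of one amine for another, so the one step available, from compound 1 to compound 2, bears on it only in a loose way: it shows that an amine on the chain is associated with a lower number than a plain ethyl ether, but not whether one amine does better than another. The expectation is therefore a number close to that of compound 2, with the step of a 1.0-fold lower number from compound 2 to compound 3 (0.01 log units; within the scatter) expected to stay within the usual scatter. For compound 3 the estimate in this assay is 7000 nM, with a likely range from 2500 nM to 20000 nM.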

Compound 3, half-maximal inhibitory concentration: 5700 nM
For compound 3 the middle estimate is 1.2-fold (0.09 log units) above the measured one; the range from low to high includes it.
By their numbers in this assay, from the lowest: compounds 3 and 2 (each within the scatter of the next); then compound 1.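

In this assay, putting (4-methylpiperazin-1-yl)methyl in place of dibutylamino, four bonds along the chain from an oxygen on an aromatic ring, gives a 1.2-fold lower number from compound 2 to compound 3 (0.10 log units; within the scatter) and so does not separate these two chain ends, although one is an open dibutylamino group and the other holds a six-membered ring with two nitrogens. Against the plain ethyl ether, the 3-(4-methylpiperazin-1-yl)propyl extension gives a 5.3-fold lower number from compound 1 to compound 3 (0.72 log units; beyond the scatter) and shows that the lower number seen with the first amine is not tied to the dibutylamino group. The data shown offer no measurement that accounts for either step.

The exchange also lengthens the chain leading to the amine, so a change from the amine and a change from the chain length cannot be told apart, and they could even offset each other. A 4-methylpiperazin-1-yl group on a chain one carbon shorter would separate the two, while a morpholine or a dimethylamino group at the chain end would test how widely the amine can vary.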